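The source may report more compounds than this note shows. Statements on the series, on what has been measured and on what is new or still open speak of the compounds shown alone.

Measured so far in a functional assay on HCT-116 cells (Homo sapiens) for antiproliferative activity, read by MTT assay, with a stated time of 48 h; a higher number here means a weaker inhibitor, a lower number a stronger inhibitor:
- compound 1 `COc1cc(N(Cc2ccccc2)C(=O)CSc2nc3ccccc3s2)cc(OC)c1OC`: 54500 nM
- compound 2 `COc1ccc(CN(C(=O)CSc2nc3ccccc3s2)c2cc(OC)c(OC)c(OC)c2)cc1O`: 182 nM

Among the measured compounds shown here, compound 2 holds the lowest number of the two measured; its nearest neighbour is compound 1, and the single measured step, a 300-fold lower number from compound 1 to compound 2 (2.48 log units; beyond the scatter), is large. Compound 3 `COc1ccc(CN(C(=O)CSc2nc3ccccc3s2)c2cc(OC)c(OC)c(OC)c2)cc1N` differs from compound 2 in one place: amino in place of hydroxy on an aromatic carbon. For the measured compounds named here, no measured step bears directly on this change. Going by the values given here, the only step on record covers 3-hydroxy-4-methoxyphenyl entering in place of phenyl and says nothing about hydroxy against amino within that group, so there is no measured reference for the size or direction of the change. With nothing to draw on, compound 3 is expected in this assay to sit near compound 2, with a step of a 1.6-fold higher number from compound 2 to compound 3 (0.22 log units; within the scatter) not expected to go beyond the scatter. Compound 3 is estimated at 300 nM, in the range 100 nM to 1500 nM.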

Compound 3, half-maximal inhibitory concentration: 491 nM
Beside the measured number, compound 3's estimate is 1.6-fold (0.21 log units) below it; the range from low to high includes it.
By their numbers in this assay, from the lowest: compound 2; then compound 3; then compound 1.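

Among the compounds shown here, exchanging hydroxy for amino on this aromatic carbon, ortho to a methoxy group, is not neutral in this assay: the change gives a 2.7-fold higher number from compound 2 to compound 3 (0.43 log units; beyond the scatter) and is the smallest step so far. The large gain over the unsubstituted benzyl group does not require hydroxy, since 3-amino-4-methoxyphenyl still gives a 110-fold lower number from compound 1 to compound 3 (2.05 log units; beyond the scatter) and 3-hydroxy-4-methoxyphenyl gives a 300-fold lower number from compound 1 to compound 2 (2.48 log units; beyond the scatter) on the same comparison. No measurement on hand accounts for the difference between hydroxy and amino.

The compounds shown leave open how much of the large gain comes from the methoxy group and how much from the hydroxy or amino group. Also open, as far as these compounds go, is whether a fluoro, a methyl or an acetamido group on the same aromatic carbon would hold the number near that of compound 2.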